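Shortening the 3-hydroxypropyl chain of compound 1 to methyl

This account rests on a few compounds, and the source may have more. Where it says the series, first, only, none or still open, it means among the compounds named here.

Among the measured compounds shown here, in a functional assay (trachea) with Cavia porcellus as the target (a lower number here means that less compound is needed, a higher number that more compound is needed for the effect), compound 1 `CCCn1c(=O)n(CCCO)c(=O)c2[nH]cnc21` gives 5100 nM, the higher of the two numbers so far, while compound 2 `CCCn1c(=O)n(CCCCC(C)=O)c(=O)c2[nH]cnc21` gives 60 nM. Compound 3 `CCCn1c(=O)n(C)c(=O)c2[nH]cnc21` has hydrogen in place of 2-hydroxyethyl on a saturated chain carbon bound to an aromatic nitrogen, so 3-hydroxypropyl becomes methyl (hydrogen in place of 2-hydroxyethyl on a saturated chain carbon bound to an aromatic nitrogen). For the measured compounds named here, only one measured step bears on this change: an 85-fold lower number from compound 1 to compound 2 (1.93 log units; beyond the scatter). That step is large and beyond the scatter, and it also removes the hydroxy group. However, it brings in 2-oxopropyl, which compound 3 lacks, so it gives only a weak guide to direction and no direct guide to size. Going by the values given here, no measured compound yet carries a methyl group at this place. A much smaller move towards a lower number is therefore expected in this assay, with the estimated step being a 2.0-fold lower number from compound 1 to compound 3 (0.31 log units; beyond the scatter). The estimate for compound 3 is 2500 nM, with an expected range of 500 nM to 12000 nM.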

Compound 3, half-maximal effective concentration: 1600 nM
For compound 3 the middle estimate is 1.6-fold (0.19 log units) above the measured one; low and high end bracket the measured number.
By their numbers in this assay, from the lowest: compound 2; then compound 3; then compound 1.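

Replacing 3-hydroxypropyl with methyl in this assay gives a 3.2-fold lower number from compound 1 to compound 3 (0.50 log units; beyond the scatter), so on this saturated chain carbon bound to an aromatic nitrogen, the chain of compound 1 offers no advantage over methyl. With methyl as the simple reference, a 27-fold higher number from compound 2 to compound 3 (1.43 log units; beyond the scatter) shows that the low number of compound 2 is tied to its 3-acetylpropyl group and is not merely the result of losing 3-hydroxypropyl. No available evidence accounts for either step.

The compounds shown do not separate the contribution of chain length from that of the ketone carbonyl in 3-acetylpropyl, and a plain butyl or pentyl chain would address that question. As far as these compounds go, it also remains open how a terminal amine or carboxylic acid on the chain would read in this assay.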